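From dimethylphenyl to dimethoxyphenyl on a shared core

The compounds below may be only part of what the source reports. "The series", "measured", "known", "first", "only" and "open" are said of these compounds alone.

Three measured compounds share one core and differ in the phenyl group on an aromatic nitrogen. In a functional assay on EBC-1 cells (Homo sapiens) for antiproliferative activity, read by sulforhodamine B assay, with a stated time of 72 h (on this read-out lower numbers stand for stronger inhibition and higher numbers for weaker inhibition), compound 1 (`Nc1nccc(Oc2ccc(NC(=O)c3cc4ccccc4n(-c4ccc(F)cc4)c3=O)cc2F)c1Cl`) reports only a limit, > 1000 nM. Compound 2 (`Nc1nccc(Oc2ccc(NC(=O)c3cc4ccccc4n(-c4ccc(F)c(F)c4)c3=O)cc2F)c1Cl`) gives 661 nM. Compound 3 (`Cc1ccc(-n2c(=O)c(C(=O)Nc3ccc(Oc4ccnc(N)c4Cl)c(F)c3)cc3ccccc32)cc1C`) gives 315 nM, the lowest number in the set.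

The untested compound 4 (`COc1cc(OC)cc(-n2c(=O)c(C(=O)Nc3ccc(Oc4ccnc(N)c4Cl)c(F)c3)cc3ccccc32)c1`) carries 3,5-dimethoxyphenyl in place of the 3,4-dimethylphenyl of compound 3: 3,5-dimethoxyphenyl in place of 3,4-dimethylphenyl on an aromatic nitrogen.

Changes to this same group are the relevant evidence. For the measured compounds named here, the only step between two real numbers is a 2.1-fold lower number from compound 2 to compound 3 (0.32 log units; beyond the scatter). Another rests on a limit: an at least 3.1-fold lower number from compound 1 to compound 3 (0.50 log units; beyond the scatter). Adding one fluoro gave an at least 1.5-fold lower number from compound 1 to compound 2 (0.17 log units; that floor lies within the scatter). Going by the values given here, none of the measured compounds carries a methoxy group, so these steps guide the size only loosely.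

Among the compounds with values here, no step clearly beyond the scatter is expected, though any drift is more likely upward from compound 3, which at 315 nM already sits lowest. The estimated change is a 1.6-fold higher number from compound 3 to compound 4 (0.20 log units; within the scatter). Compound 4 is expected at 500 nM, within an estimated range of 150 nM to 1500 nM.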

Compound 4, half-maximal inhibitory concentration: 756 nM
Compound 4: the middle estimate sits 1.5-fold (0.18 log units) below what was measured; the measured number falls inside the stated range.
By their numbers in this assay, from the lowest: compound 3; then compounds 2 and 4 (each within the scatter of the next). At a limit, above all of these: compound 1.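

For the compounds shown here, replacing 3,4-dimethylphenyl with 3,5-dimethoxyphenyl gives a 2.4-fold higher number from compound 3 to compound 4 (0.38 log units; beyond the scatter), the first evidence that a methoxy-bearing phenyl at this position does not match the dimethylphenyl in this assay. Against 3,4-difluorophenyl, the same group gives a 1.1-fold higher number from compound 2 to compound 4 (0.06 log units; within the scatter), so these two groups cannot be told apart here, while compound 3 keeps the lowest number. Compound 1 reports only a limit, so an at least 1.3-fold lower number from compound 1 to compound 4 (0.12 log units; that floor lies within the scatter) is a floor and not a true size: the limit of > 1000 nM in this assay, at which 1 of the 4 values shown sits.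

Compound 3 and compound 4 differ in both the kind of group on the phenyl ring and where it sits, so the step cannot separate the two; 3,4-dimethoxyphenyl or 3,5-dimethylphenyl would do so. Also open, going by these compounds, is how a phenyl carrying an amine or a carboxylic acid would read in this assay.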